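Flipping the Double-Bond Geometry of Compound 3

A few compounds are considered here, and "the series" means these few. Any claim that something is new, unique, unknown or untested is made for them only; others in the source may bear on it.

Three compounds have been measured in a functional assay on HeLa cells (Homo sapiens) for inhibition, read by sulforhodamine B assay, with a stated time of 48 h; a higher number here means a weaker inhibitor of growth, a lower number a stronger inhibitor of growth:
compound 1, `O=C(/C(=C/c1ccc(Cl)cc1Cl)CCl)c1ccccc1`, gives 15000 nM;
compound 2, `O=C(OC/C(=C\C1CCCCC1)C(=O)c1ccccc1)c1ccccc1`, gives 24000 nM;
compound 3, `O=C(OC/C(=C\c1ccc(Cl)cc1Cl)C(=O)c1ccccc1)c1ccccc1`, gives 20000 nM.

Compound 3 stands second highest of these three numbers. Both steps leading to it, a 1.3-fold higher number from compound 1 to compound 3 (0.12 log units; within the scatter) and a 1.2-fold lower number from compound 2 to compound 3 (0.08 log units; within the scatter), lie within the usual scatter, so the three numbers cannot be told apart on this evidence; each change, a benzoyloxy in place of a chloro on the saturated chain carbon, or a 2,4-dichlorophenyl in place of a cyclohexyl at the double bond, left the growth-inhibiting concentration essentially where it was.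

Compound 4, `O=C(OC/C(=C/c1ccc(Cl)cc1Cl)C(=O)c1ccccc1)c1ccccc1`, differs from compound 3 in one way only: the two compounds have the same atoms and bonds and differ only in configuration as drawn: 1 of 1 stereo elements differ; a double bond is drawn E in compound 3 and Z in compound 4. For the measured compounds named here, no measured pair among the three compounds differs in double-bond geometry, so neither step bears directly on this change. The two steps that are known both stayed within the scatter, and nothing in the data points toward a shift in either direction. Compound 4 is expected to give 20000 nM in this assay, estimated to fall between 7000 nM and 55000 nM. This estimate means a step of no change at the digits printed from compound 3 to compound 4 (within the scatter), expected to be no change beyond the scatter, with wide uncertainty since geometry has not been tested here.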

Compound 4, concentration for 50% growth inhibition: 8300 nM
Estimate against measurement, compound 4: 2.4-fold (0.38 log units) above; the measured number falls inside the stated range.
By their numbers in this assay, from the lowest: compounds 4, 1, 3 and 2 (each within the scatter of the next, the first and the last beyond it).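

Turning the double bond from E to Z gave a 2.4-fold lower number from compound 3 to compound 4 (0.38 log units; beyond the scatter) in this assay, the first step shown to leave the scatter, whereas replacing a group on the saturated chain carbon or at the double bond did not. The step is modest, but it can be pinned on the geometry alone, since this pair has a single point of difference: the fact that compounds 3 and 4 differ only in the configuration as drawn. The arrangement at this double bond can therefore shift the number even when no atom changes.

Going by these compounds, whether the same flip gives a similar step with cyclohexyl in place of 2,4-dichlorophenyl, or with chloro in place of benzoyloxy, stays open. So does the effect on the number of an amine or a carboxylic acid in place of benzoyloxy with the Z geometry kept.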